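Swapping Methyl for tert-Butyl on an Amide-Linked Phenyl Ring

The source may report more compounds than this note shows. Statements on the series, on what has been measured and on what is new or still open speak of the compounds shown alone.

Measured so far:
Compound 1, `O=C(COc1ccc2c(=O)ccoc2c1)Nc1cccc(NC(=O)c2ccccc2)c1`: 120 nM in an assay on isolated protein for inhibition of Rho-associated protein kinase 1 (Homo sapiens), read by scintillation counting, radiometric assay and 33P incorporation, with a stated time of 40 min, in the presence of a further agent that is not named here; a higher number here means a weaker inhibitor, a lower number a stronger inhibitor
Compound 2, `Cc1ccc(C(=O)Nc2cccc(NC(=O)COc3ccc4c(=O)ccoc4c3)c2)cc1`: 183 nM in this assay

Compound 1 and compound 2 share one core and differ only at a single aromatic carbon, where compound 2 carries a methyl in place of hydrogen. The step between them, a 1.5-fold higher number from compound 1 to compound 2 (0.18 log units; within the scatter), lies within the scatter of the measurement, so on these numbers the two compounds cannot be set apart from each other.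

Compound 3, `CC(C)(C)c1ccc(C(=O)Nc2cccc(NC(=O)COc3ccc4c(=O)ccoc4c3)c2)cc1`, has not yet been measured. It differs from compound 2 by tert-butyl in place of methyl on an aromatic carbon. Going by the values given here, only one measured step bears on this change, the step of a 1.5-fold higher number from compound 1 to compound 2 (0.18 log units; within the scatter), and it was within the scatter: adding a methyl at this carbon left the number essentially where it was. Among the compounds with values here, a tert-butyl at the same carbon has no measured precedent here, so the expectation rests on that single step and carries a wide range. The estimated step is a 1.4-fold higher number from compound 2 to compound 3 (0.14 log units; within the scatter), which is expected to stay near the scatter. Compound 3 is expected to give about 250 nM in this assay, with a range from 100 nM to 700 nM.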

Compound 3, half-maximal inhibitory concentration: 165 nM
The estimate for compound 3 lay 1.5-fold (0.18 log units) above the measured number, within the range that was stated.
By their numbers in this assay, from the lowest: compounds 1, 3 and 2 (each within the scatter of the next).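

Going from methyl, with 1 heavy atom, to tert-butyl, with 4 heavy atoms, gives a 1.1-fold lower number from compound 2 to compound 3 (0.04 log units; within the scatter) in this assay, and putting tert-butyl in place of the hydrogen of compound 1 gives a 1.4-fold higher number from compound 1 to compound 3 (0.14 log units; within the scatter) in the same test. The earlier methyl step covered only one small addition, whereas these steps show that a much larger carbon group at this aromatic carbon, para to a large group, also leaves the number within the scatter, so hydrogen, methyl and tert-butyl cannot be told apart here on these numbers. No accompanying measurement gives a reason for this flat result.

Methyl and tert-butyl are both plain carbon groups with 0 hydrogen-bond donors and 0 hydrogen-bond acceptors, so the compounds shown leave open whether an amine, a carboxylic acid or a methoxy group at this carbon would move the number beyond the scatter. They also leave open whether this tolerance extends to the other carbons of the same ring, since every substituent shown sits at this one place.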